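Fluoro for chloro on the benzylidene ring of compound 1

The source may hold more compounds than are shown below. What is called first, only, known or untested is meant among the compounds shown, and "the series" means these compounds.

Measured compounds:
- compound 1, `O=C1/C(=C/c2ccccc2Cl)Cc2ccccc21` — 152000 nM in a functional assay on L1210 cells (Mus musculus) for inhibition; a higher number here means a weaker inhibitor, a lower number a stronger inhibitor
- compound 2, `O=C1/C(=C/c2ccc(Cl)cc2Cl)CCCc2ccccc21` — > 500000 nM in this assay

Of the compounds shown here, two have been measured. Within the data shown here, compound 1 gives 152000 nM in this assay, the only actual number in the set. Compound 2, with a different core and a second chlorine, reaches only a limit of the assay, > 500000 nM; that limit is one of the two values shown (the limit of > 500000 nM in this assay, at which 1 of the 2 values shown sits). Among the measured compounds shown here, compound 1 therefore stands as the sole numeric anchor, and no step between measured compounds of single-point difference exists.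

Compound 3, `O=C1/C(=C/c2ccccc2F)Cc2ccccc21`, is not yet measured. It differs from compound 1 by fluoro in place of chloro on an aromatic carbon. For the measured compounds named here, the data hold no measured step of this kind. No direction is supported beyond the usual scatter. The expected step of a 1.3-fold higher number from compound 1 to compound 3 (0.12 log units; within the scatter) is small, within that scatter. Compound 3 is estimated at 200000 nM, with a range from 60000 nM to 600000 nM.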

Compound 3, half-maximal inhibitory concentration: 150000 nM
Compound 3: middle estimate off by 1.3-fold (0.12 log units), on the high side; measured number inside the range.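

The exchange of chloro for fluoro gives the set its first step between compounds that differ in one place, and in this assay it reads a 1.0-fold lower number from compound 1 to compound 3 (0.01 log units; within the scatter). On this aromatic carbon, ortho to a large group, the two halogens therefore cannot be told apart in this read-out, something compound 1 alone could not show. Nothing at hand bears on why they read alike.

The compounds shown leave open whether a different group on this carbon, such as a methoxy group, an amine or a carboxylic acid, would shift the number. Going by these compounds, compound 2 differs from the others in more than one place, so the separate contributions of its core and its second chlorine also remain open.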